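The source may report more compounds than this note shows. Statements on the series, on what has been measured and on what is new or still open speak of the compounds shown alone.

Working notes on the series.

Compound 1 `COCCNC(=C\C(=O)/C=C/c1ccc(O)cc1)/C=C/c1ccc(O)cc1` is the parent. Compound 2 `COCCNC(=C\C(=O)/C=C/c1ccc(O)c(OC)c1)/C=C/c1ccc(O)c(OC)c1` carries a different core; how the two cores differ is not broken down here. Compound 3 `COCCCNC(=C\C(=O)/C=C/c1ccc(O)cc1)/C=C/c1ccc(O)cc1` is made from compound 1 by methoxymethyl in place of methoxy on a saturated chain carbon, two bonds along the chain from an amine nitrogen. Compound 4 `COCCCNC(=C\C(=O)/C=C/c1ccc(O)c(OC)c1)/C=C/c1ccc(O)c(OC)c1` is the counterpart of compound 3 on the core of compound 2 and is not yet measured.

In a physicochemical assay for solubility, using the shake flask method, in phosphate buffer, with a stated time of 90 min, at pH 6.8 (a lower number here means a less soluble compound, a higher number a more soluble compound), compound 1 gives 37500 nM. In this assay compound 3 gives 10500 nM, and compound 2 gives 16700 nM, a number within the scatter of compound 3 and beyond it relative to compound 1. Going by the values given here, the one step measured so far is a 3.6-fold lower number from compound 1 to compound 3 (0.55 log units; beyond the scatter).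

Compound 4 is made from compound 2 by methoxymethyl in place of methoxy on a saturated chain carbon, two bonds along the chain from an amine nitrogen. The place is the same in both cases, so this is the same change applied to a second core; it has been seen once, in the step from compound 1 to compound 3. On that single step, the expected step from compound 2 to compound 4 is a 3.3-fold lower number from compound 2 to compound 4 (0.52 log units; beyond the scatter), though the core of compound 2 gives no further support. Compound 4 is therefore estimated at 5000 nM in this assay, with a range of 2300 nM to 11000 nM.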

Compound 4, solubility: 7700 nM
Beside the measured number, compound 4's estimate is 1.5-fold (0.19 log units) below it; the range from low to high includes it.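

In this assay the change of methoxy to methoxymethyl, on a saturated chain carbon, two bonds along the chain from an amine nitrogen, gives a 2.2-fold lower number from compound 2 to compound 4 (0.34 log units; beyond the scatter), which runs the same way as a 3.6-fold lower number from compound 1 to compound 3 (0.55 log units; beyond the scatter), and both steps lie beyond the scatter. This shows a shared direction on the two cores at hand, but with one step on each core it does not show that the size of the step carries over, nor that the direction would hold on any other core. Nothing measured here bears on what lies behind the lower number on either core.

The compounds shown leave open how the number in this assay moves with a chain longer than 3-methoxypropyl, or with an amine or a carboxylic acid in place of the methoxy group. On these data alone, whether the step keeps its direction on a third core also remains open.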